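Compound 3 after two results at the assay limit

A few compounds are considered here, and "the series" means these few. Any claim that something is new, unique, unknown or untested is made for them only; others in the source may bear on it.

compound 1 `CCOC(=O)c1c(-c2cccc(OC)c2)[nH]c2cc(OC)ccc2c1=O` gives > 22000 nM
compound 2 `CCOC(=O)c1c(-c2cccc(C(C)=O)c2)[nH]c2cc(OC)ccc2c1=O` gives > 22000 nM

In an ADME assay on HEK293 cells (Homo sapiens) for cytotoxicity, read by luminescence, with a stated time of 72 h (on this read-out lower numbers stand for an effect already at smaller amounts and higher numbers for an effect only at larger amounts of compound), compound 2 gives > 22000 nM as a limit, not a number. Compound 1 gives > 22000 nM as a limit too. Compound 3 `CCOC(=O)c1c(-c2cccc(S(C)(=O)=O)c2)[nH]c2cc(OC)ccc2c1=O` carries methylsulfonyl in place of acetyl on an aromatic carbon and otherwise keeps the core of compound 2. Among the compounds with values here, the one measured step is a step that the two limits leave unreadable from compound 1 to compound 2 and offers no size to carry over. Within the data shown here, the only evidence is the limit of > 22000 nM in this assay, at which 2 of the 2 values shown sit, and it points to no particular direction. In this assay no step beyond the scatter is therefore expected. The expected change is a step that the limit leaves unreadable from compound 2 to compound 3 and it remains an estimate. Compound 3 is estimated at 30000 nM within an expected range from 15000 nM to 60000 nM and will probably be reported as a limit again.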

Compound 3, half-maximal effective concentration: > 22000 nM
Compound 3: only a limit was reported (the forecaster's own chance of this, stated with the estimate: 85%); the middle value lies beyond the limit too.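

Within the data shown here, compound 1, compound 2 and compound 3 all gave a limit rather than a number, so no step among them can be read. On these data alone, whether methoxy, acetyl and methylsulfonyl differ at all in their effect remains open.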